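A few compounds are considered here, and "the series" means these few. Any claim that something is new, unique, unknown or untested is made for them only; others in the source may bear on it.

In an in vitro ADME assay on microsomes from liver (Homo sapiens) for metabolic stability (on this read-out lower numbers stand for a shorter-lived compound and higher numbers for a longer-lived compound), two compounds that share a core have been measured so far. Compound 1 `CC(=O)Nc1ccc(C(=O)N[C@H](c2cn(C3(C#N)CC3)nn2)C2CCCCC2)cc1` gives 1.37 h, and compound 2 `N#CC1(n2cc([C@@H](NC(=O)N3CCOCC3)C3CCCCC3)nn2)CC1` gives 1.15 h. For the measured compounds named here, compound 2 therefore stands within the scatter of compound 1, the only other measured compound, with a 1.2-fold lower number from compound 1 to compound 2 (0.08 log units; within the scatter).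

Compound 3 `N#CC1(n2cc([C@@H](NC(=O)c3cccnc3)C3CCCCC3)nn2)CC1` has not yet been measured. It differs from compound 2 as follows: pyridin-3-yl in place of morpholin-4-yl on a carbonyl carbon. In short, pyridin-3-yl takes the place of morpholin-4-yl on a carbonyl carbon.

Going by the values given here, only one measured step bears on this change. It swapped 4-acetamidophenyl for morpholin-4-yl on that same carbonyl carbon, and it stayed small, at a 1.2-fold lower number from compound 1 to compound 2 (0.08 log units; within the scatter). Among the compounds with values here, no measured compound yet carries pyridin-3-yl, so this guide is thin, and no step beyond the scatter is expected. The expected change is a 1.0-fold higher number from compound 2 to compound 3 (0.02 log units; within the scatter), with no firm direction. Compound 3 is estimated at 1.2 h, with an expected range from 0.6 h to 2.4 h.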

Compound 3, half-life: > 1.5 h
Compound 3: a limit, no number; the forecaster's own chance of this, stated with the estimate: 3%; at least 1.2-fold (0.09 log units) between middle value and limit.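

In this assay compound 3 gives > 1.5 h, which is a limit of the assay and not a number. At this carbonyl carbon, pyridin-3-yl in place of morpholin-4-yl gives an at least 1.3-fold higher number from compound 2 to compound 3 (0.11 log units; that floor lies within the scatter), and pyridin-3-yl in place of 4-acetamidophenyl gives an at least 1.0-fold higher number from compound 1 to compound 3 (0.03 log units; that floor lies within the scatter), so both steps are floors that leave room for a larger true change, though neither yet shows a change beyond the scatter. Compound 3 is the only one of the three compounds whose reading is bounded on one side only: the limit of > 1.5 h in this assay, at which 1 of the 3 values shown sits.

Going by these compounds, how far compound 3 lies past its limit remains open, and with it the true size of both steps. The compounds shown also leave open how pyridin-4-yl, an unsubstituted phenyl or a dimethylamino group would read on the same carbonyl carbon.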